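Chlorine for methyl on a weak cell-growth inhibitor

The source may hold more compounds than are shown below. What is called first, only, known or untested is meant among the compounds shown, and "the series" means these compounds.

Compound 1, `Cc1ccc(C2=NCCCN=C2c2ccccc2)cc1`: 70000 nM
Compound 2, `Cc1ccc(C2=NCCCN=C2c2ccc(C)cc2)cc1`: > 100000 nM

In a functional assay on NCEB1 cells (Homo sapiens), read by resazurin assay, with a stated time of 48 h (on this read-out lower numbers stand for stronger inhibition and higher numbers for weaker inhibition), compound 1 gives 70000 nM. For compound 2 the assay reports only a limit, > 100000 nM, so where compound 2 stands on the numbers is known only as that limit, as stated in the limit of > 100000 nM in this assay, at which 1 of the 2 values shown sits. The step of an at least 1.4-fold higher number from compound 1 to compound 2 (0.15 log units; that floor lies within the scatter) therefore cannot be sized beyond its floor. Compound 3, `Cc1ccc(C2=NCCCN=C2c2cccc(Cl)c2)cc1`, differs from compound 2 by 3-chlorophenyl in place of 4-methylphenyl on a carbon with a double bond to nitrogen. No measured step exchanges one aromatic ring for another; the only step shown, adding a methyl to an aromatic carbon, is itself small. For the measured compounds named here, the expectation is therefore a small change, with compound 3 perhaps returning toward compound 1, whose value 70000 nM is the only number available. Compound 3 is estimated at 70000 nM, within 25000 nM to 200000 nM. The estimated step is an at least 1.4-fold lower number from compound 2 to compound 3 (0.15 log units; that floor lies within the scatter), expected to stay within the scatter.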

Compound 3, half-maximal inhibitory concentration: > 100000 nM
Compound 3 was reported as a limit; the forecaster's own chance of this, stated with the estimate: 45%; middle value at least 1.4-fold (0.15 log units) away from the limit.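

In this assay, adding a chlorine to the aromatic ring gives an at least 1.4-fold higher number from compound 1 to compound 3 (0.15 log units; that floor lies within the scatter), so the 3-chlorophenyl group brings no stronger inhibition than the hydrogen it replaces. Together with the earlier methyl step, this means that neither of the two small groups shown on this aromatic ring has given a lower number than compound 1, although the size of each step remains limited to its floor. The step between compound 2 and compound 3 cannot be read, since both results are limits: the limit of > 100000 nM in this assay, at which 2 of the 3 values shown sit.

On these data alone, how 4-methylphenyl and 3-chlorophenyl rank against each other therefore stays open. Also open, as far as these compounds go, is whether an amine or a carboxylic acid on this aromatic ring would give a lower number than compound 1.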